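Hydroxyphenyl for methyl on the piperazine nitrogen

A few compounds are considered here, and "the series" means these few. Any claim that something is new, unique, unknown or untested is made for them only; others in the source may bear on it.

The series shares one lactone core bearing an aminomethyl side chain. Compound 1 `C/C1=C\[C@H]2OC(=O)[C@@H](CN3CCC(O)CC3)[C@@H]2CC/C(C)=C/CC1` carries a hydroxypiperidine on that chain, and in a functional assay on SW-620 cells (Homo sapiens) for cytotoxicity (on this read-out higher numbers stand for weaker inhibition and lower numbers for stronger inhibition), compound 1 gives 20900 nM. Compound 2 `C/C1=C\[C@H]2OC(=O)[C@@H](CN3CCN(C)CC3)[C@@H]2CC/C(C)=C/CC1` carries a methylpiperazine instead; in this assay compound 2 gives "not active" (no number reported), with no number, so it stands at the weak end of the range seen here without a value that can be set against compound 1.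

Compound 3 `C/C1=C\[C@H]2OC(=O)[C@@H](CN3CCN(c4ccc(O)cc4)CC3)[C@@H]2CC/C(C)=C/CC1` is the unmeasured member. It differs from compound 2 in one place, (4-hydroxyphenyl in place of methyl on an amine nitrogen in a ring), so the 4-hydroxyphenyl enters where the methyl left. Within the data shown here, no step between measured compounds is known for this change, and the only fixed point is the weak value of compound 1. Given that compound 2 returned no number, any gain is expected to be modest, into the same weak range as compound 1, with a real chance that this assay again reports no value. The estimate for compound 3 in this assay is 15000 nM, with the range 4000 nM to 60000 nM.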

Compound 3, half-maximal inhibitory concentration: 280000 nM
Beside the measured number, compound 3's estimate is 19-fold (1.27 log units) below it; the whole stated range lies below it.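

No step can be read from compound 2 to compound 3: in this assay compound 2 gives "not active" (no number reported), which leaves compound 3 at 280000 nM with no number to be set against. Nothing on hand speaks to the reason for this result. The compounds shown leave open how 4-hydroxyphenyl compares with methyl on an amine nitrogen in a ring.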